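A few compounds are considered here, and "the series" means these few. Any claim that something is new, unique, unknown or untested is made for them only; others in the source may bear on it.

Compound 1 `Cc1ccsc1-c1cc(-c2ccoc2)cc(-c2ccco2)n1`: 23300 nM
Compound 2 `Cc1ccsc1-c1cc(-c2ccc(Cl)o2)cc(-c2ccco2)n1`: 10600 nM

Within the data shown here, in a functional assay on K562 cells (Homo sapiens) for cytotoxicity, read by ELISA, with a stated time of 4 days (on this read-out higher numbers stand for weaker inhibition and lower numbers for stronger inhibition), compound 2 holds the lower of the two numbers so far at 10600 nM, and compound 1 stands at 23300 nM. Neither number shows strong inhibition in absolute terms, and two compounds are too few to reveal a trend.

The next compound is compound 3 `Cc1ccsc1-c1cc(-c2ccc(Cl)o2)cc(-c2cccc(Cl)c2)n1`, which keeps the 5-chlorofuran-2-yl group of compound 2 and changes another position: 3-chlorophenyl in place of furan-2-yl on an aromatic carbon. Put simply, 3-chlorophenyl comes in place of furan-2-yl on an aromatic carbon.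

Among the measured compounds shown here, only one measured step offers any guide, a 2.2-fold lower number from compound 1 to compound 2 (0.34 log units; beyond the scatter). It is modest, and it was made at a different place on the shared core, so it says nothing direct about this position. It does show that a chlorine-bearing group went with a lower number there, and it suggests the scale of change to expect. A modest move towards a lower number in this assay is therefore expected, held with little confidence, and the estimated step is a 1.5-fold lower number from compound 2 to compound 3 (0.18 log units; within the scatter). For compound 3 the estimated value is 7000 nM, with an expected range from 2000 nM to 20000 nM.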

Compound 3, half-maximal inhibitory concentration: 13400 nM
Estimate against measurement, compound 3: 1.9-fold (0.28 log units) below; low and high end bracket the measured number.
By their numbers in this assay, from the lowest: compounds 2, 3 and 1 (each within the scatter of the next, the first and the last beyond it).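

In this assay, putting 3-chlorophenyl in place of furan-2-yl next to the ring nitrogen gives a 1.3-fold higher number from compound 2 to compound 3 (0.10 log units; within the scatter) and so leaves the two compounds indistinguishable on this read-out. For this pair, a group of 7 heavy atoms with a chlorine and no hydrogen-bond acceptor can stand where a group of 5 heavy atoms with 1 hydrogen-bond acceptor stood, without a change that rises above the usual scatter. This suggests that, with the 5-chlorofuran-2-yl group in place, the oxygen of the furan-2-yl ring is not needed to keep the number where it is, although no measurement at hand explains the result.

The compounds shown leave open whether the chlorine of the 3-chlorophenyl group matters at all, a question that a plain phenyl ring at this position could help to answer. They also leave open how this position would respond to a different kind of group, such as an amine or a carboxylic acid, and whether any change here could bring the number much lower.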